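The source may report more compounds than this note shows. Statements on the series, on what has been measured and on what is new or still open speak of the compounds shown alone.

Working notes on the series in a functional assay on ECa-109 cells (Homo sapiens) for cytotoxicity, read by MTT assay, with a stated time of 72 h; a lower number here means a stronger inhibitor, a higher number a weaker inhibitor.

The shared core carries two 4-chlorophenyl groups, and the measured compounds differ only in the group on the exocyclic double bond. Compound 1 `CC(C)=C1C(=O)N(c2ccc(Cl)cc2)N(c2ccc(Cl)cc2)C1=O` gives 42100 nM. Within the data shown here, compound 3 `CC(=C1C(=O)N(c2ccc(Cl)cc2)N(c2ccc(Cl)cc2)C1=O)c1ccc(O)cc1` gives 55600 nM; the one step measured so far, a 1.3-fold higher number from compound 1 to compound 3 (0.12 log units; within the scatter), stays within the scatter. Compound 2 `COc1cccc(C=C2C(=O)N(c3ccc(Cl)cc3)N(c3ccc(Cl)cc3)C2=O)c1O` gives 39000 nM, and its numbers against compound 1 and compound 3 both sit within the scatter, so the three measured compounds are not separated from one another in this assay.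

Compound 4 `O=C1C(=C/C=C/c2ccccc2)C(=O)N(c2ccc(Cl)cc2)N1c1ccc(Cl)cc1` has not been measured. It differs from compound 2 as follows: 2-phenylethenyl in place of 2-hydroxy-3-methoxyphenyl on a double-bonded chain carbon bound to a double-bonded ring carbon. Among the measured compounds shown here, no measured step covers a 2-phenylethenyl group, and the only step available, from compound 1 to compound 3, bears on the change only loosely, since it too swaps the group on the double-bonded chain carbon and stays within the scatter. The expectation is therefore no step beyond the scatter, estimated as a 1.2-fold higher number from compound 2 to compound 4 (0.06 log units; within the scatter). Compound 4 is expected to give 45000 nM, with a range of 18000 nM to 110000 nM.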

Compound 4, half-maximal inhibitory concentration: 9900 nM
Compound 4: middle estimate off by 4.5-fold (0.66 log units), on the high side; the measured number lies below the stated range.
By their numbers in this assay, from the lowest: compound 4; then compounds 2, 1 and 3 (each within the scatter of the next).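

Among these compounds, at this position, on a double-bonded chain carbon bound to a double-bonded ring carbon, the group can shift the number in this assay: the change to 2-phenylethenyl gives a 3.9-fold lower number from compound 2 to compound 4 (0.60 log units; beyond the scatter) and is the first step beyond the scatter, though a modest one. The single step shown earlier, a 1.3-fold higher number from compound 1 to compound 3 (0.12 log units; within the scatter), gave no such sign. This one change removes the hydroxy and methoxy groups and brings in a double bond outside aromatic rings, so the step cannot assign the shift to either part, and no available evidence bears on its cause.

Open, from the compounds shown here alone, is whether a plain phenyl group at this place would track compound 2 or compound 4. Also open, going by these compounds, is whether a longer chain, such as 4-phenylbuta-1,3-dienyl, would carry the shift further.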